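The compounds below may be only part of what the source reports. "The series", "measured", "known", "first", "only" and "open" are said of these compounds alone.

Measured in a functional assay on MCF7 cells (Homo sapiens) for inhibition, read by MTT assay, with a stated time of 72 h; on this read-out higher numbers stand for weaker inhibition and lower numbers for stronger inhibition:
- compound 1 `Nc1ncnc2c1c(-c1cnc3[nH]ccc3c1)nn2CCCCCCCCC(=O)NO`: 24700 nM
- compound 2 `Nc1nc2cc(-c3nn(CCCCCCCCC(=O)NO)c4ncnc(N)c34)ccc2o1`: 42100 nM

Among the measured compounds shown here, only one step is measured: a 1.7-fold higher number from compound 1 to compound 2 (0.23 log units; within the scatter). The two compounds therefore stand level, with no ranking between them. That step changes a group on an aromatic carbon and leaves the chain untouched, so nothing measured speaks to chain length.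

Compound 3 `Nc1ncnc2c1c(-c1cnc3[nH]ccc3c1)nn2CCCC(=O)NO` differs from compound 1 in the chain: hydroxycarbamoyl in place of 5-(hydroxycarbamoyl)pentyl on a saturated chain carbon, three bonds along the chain from an aromatic nitrogen.

With that gap, the expectation rests on compound 1 at 24700 nM, and no change beyond the scatter is expected in this assay. The expected step is a 1.2-fold higher number from compound 1 to compound 3 (0.08 log units; within the scatter). The estimate for compound 3 is 30000 nM, with an expected range from 9000 nM to 90000 nM.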

Compound 3, half-maximal inhibitory concentration: > 150000 nM
Compound 3: only a limit was reported (the forecaster's own chance of this, stated with the estimate: 25%); at least 5.0-fold (0.69 log units) between middle value and limit.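

Chain length on the shared core now matters, where the earlier pair spoke only to a group on an aromatic carbon. In this assay, hydroxycarbamoyl in place of 5-(hydroxycarbamoyl)pentyl gives an at least 6.0-fold higher number from compound 1 to compound 3 (0.78 log units; beyond the scatter), the only step shown that lies beyond the scatter. For compound 3, > 150000 nM is a limit and not a number, so the step gives only a minimum size: the limit of > 150000 nM in this assay, at which 1 of the 3 values shown sits.

The compounds shown leave open how the number moves with intermediate chain lengths or a longer chain. They also leave open whether a carboxylic acid could replace the hydroxycarbamoyl end.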